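A few compounds are considered here, and "the series" means these few. Any claim that something is new, unique, unknown or untested is made for them only; others in the source may bear on it.

In a functional assay on L02 cells (Homo sapiens) for inhibition, read by Griess assay, with stated times of 1 h and 24 h (a higher number here means a weaker inhibitor, a lower number a stronger inhibitor), compound 1 (`CNc1nc(/C=C/c2ccccc2)nc2ccsc12`) gives > 1000000 nM, and this is a limit of the assay, not a number. For the measured compounds named here, compound 2 (`CNc1nc(/C=C/c2ccco2)nc2ccsc12`) gives 811000 nM, the only true number so far, so there is little to rank it against. The next compound, compound 3 (`C(=C/c1ccco1)\c1nc(NC2CC2)c2sccc2n1`), keeps the furan-2-yl group of compound 2 and alters the amine, a change of methylamino to cyclopropylamino. The counted difference is cyclopropyl in place of methyl on a nitrogen on an aromatic ring. Going by the values given here, only one measured step exists: an at least 1.2-fold lower number from compound 1 to compound 2 (0.09 log units; that floor lies within the scatter). That step swaps a group on a double-bonded chain carbon and leaves the nitrogen untouched, so it bears only indirectly on the new change. Among the compounds with values here, no measured step yet shows what a change on that nitrogen does in this assay. With so little to go on, the sensible expectation is no clear shift, and the value of compound 2 at 811000 nM is the best starting point. The expected move is a 1.4-fold lower number from compound 2 to compound 3 (0.13 log units; within the scatter), which would not stand out from the scatter. For compound 3 the estimate is 600000 nM, with an expected range of 200000 nM to 1000000 nM.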

Compound 3, half-maximal inhibitory concentration: > 1000000 nM
Compound 3 gave a limit, no number; the forecaster's own chance of this, stated with the estimate: 30%; middle value at least 1.6-fold (0.22 log units) from the limit.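

In this assay compound 3 gives > 1000000 nM, which is a limit of the assay and not a number. For the compounds shown here, this is the first change on the nitrogen, and cyclopropyl in place of methyl gives an at least 1.2-fold higher number from compound 2 to compound 3 (0.09 log units; that floor lies within the scatter), so this swap brings no lower number and no gain in inhibition can be seen. The true size of the step cannot be read, and compound 3 cannot be ranked any more finely, because its result is only a limit: the limit of > 1000000 nM in this assay, at which 2 of the 3 values shown sit.

Going by these compounds, what a smaller or more polar change on this nitrogen would do stays open, for example a plain amino group, an ethyl group or a hydroxyethyl chain, and any of these might show whether the nitrogen can move the number at all. With compound 2 still the only true number, the compounds shown also leave open whether cyclopropyl would behave the same way on a core carrying a group other than furan-2-yl on the chain, such as a pyridine ring.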